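Bromoethenyl for methyl on the shared core: expected inhibition

The source may hold more compounds than are shown below. What is called first, only, known or untested is meant among the compounds shown, and "the series" means these compounds.

Compound 1 `Cc1cn(COCCO)c(=O)[nH]c1=O` is the reference point of the series. In a functional assay on L1210 cells (Mus musculus) for inhibition (a higher number here means a weaker inhibitor, a lower number a stronger inhibitor), compound 1 reaches only a limit of the assay, > 1000 ug/mL. Compound 2 `O=c1cc(O)ccn1COCCO` likewise gives only a limit in this assay, namely > 1000 ug/mL. Within the data shown here, both known values therefore sit at the limit of > 1000 ug/mL in this assay, at which 2 of the 2 values shown sit, and no step between measured compounds can be sized; there is no evidence here that any change shifts inhibition.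

Compound 3 `O=c1[nH]c(=O)n(COCCO)cc1/C=C/Br` remains to be measured in this assay. It differs from compound 1 by 2-bromoethenyl in place of methyl on an aromatic carbon. With nothing measured that speaks for a gain, the step from compound 1 to compound 3 is expected to amount to a number no higher from compound 1 to compound 3 (the limit leaves the size open), no more than the scatter in either direction. Compound 3 is accordingly estimated at 1000 ug/mL in this assay, within a range from 200 ug/mL to 3000 ug/mL, and most likely reported again only as a limit.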

Compound 3, concentration for 50% inhibition: > 1000 ug/mL
Compound 3 was reported as a limit; the forecaster's own chance of this, stated with the estimate: 75%; the middle value sits exactly at the limit.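

No size can be read for the step between compound 1 and compound 3, as both are reported only as limits in this assay. The compounds shown leave open whether 2-bromoethenyl in place of methyl, or any other change on the shared core, shifts inhibition at all: the limit of > 1000 ug/mL in this assay, at which 3 of the 3 values shown sit.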